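Chloro for methoxy on the aryl ring of compound 1

The compounds below may be only part of what the source reports. "The series", "measured", "known", "first", "only" and "open" are said of these compounds alone.

Measured so far:
- compound 1 `COc1ccc(-c2ccc(C(O)(c3c[nH]cn3)C(C)C)cc2)cc1`: 54 nM
- compound 2 `CC(C)C(O)(c1cccc(-c2ccc(F)cc2)c1)c1c[nH]cn1`: 19 nM

Two compounds of the series have numbers in an assay on isolated protein for inhibition of steroid 17-alpha-hydroxylase/17,20 lyase (Homo sapiens); a lower number here means a stronger inhibitor, a higher number a weaker inhibitor. Compound 1 gives 54 nM and stands with the higher of the two numbers; compound 2 gives 19 nM, a lower number, and the gap between them lies beyond the scatter. Among the compounds with values here, no single-change step between measured compounds is available, so the effect of the change at hand has not been seen directly.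

Compound 3 `CC(C)C(O)(c1ccc(-c2ccc(Cl)cc2)cc1)c1c[nH]cn1` keeps the shared core of compound 1 and differs from it in one place: chloro in place of methoxy on an aromatic carbon. Within the data shown here, with no measured step of this kind to lean on, the expectation for compound 3 in this assay is an estimate only, and the step from compound 1 is expected to be small, a 1.8-fold lower number from compound 1 to compound 3 (0.26 log units; within the scatter), pointing toward a somewhat lower number. Compound 3 is accordingly expected to give about 30 nM, with a plausible range from 12 nM to 80 nM.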

Compound 3, half-maximal inhibitory concentration: 28 nM
For compound 3 the middle estimate is 1.1-fold (0.03 log units) above the measured one; low and high end bracket the measured number.
By their numbers in this assay, from the lowest: compounds 2, 3 and 1 (each within the scatter of the next, the first and the last beyond it).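

In this assay, the series now has its first single-change step: going from 4-methoxyphenyl to 4-chlorophenyl gives a 1.9-fold lower number from compound 1 to compound 3 (0.29 log units; within the scatter). On this aromatic carbon, para to a large group, chloro in place of methoxy takes away one hydrogen-bond acceptor and one heavy atom, yet the two numbers remain within the scatter of each other, so this single exchange gives no sign that the acceptor of the methoxy group is needed here. No supporting measurement bears on how this exchange acts in the assay.

The compounds shown leave open whether this position accepts groups of other kinds, such as an amine, a carboxylic acid or a nitrile, or a longer chain in place of methoxy. They also leave open whether chloro for methoxy gives a similar step on a different core.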